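Trading a Dimethoxyphenyl Amide for a Chloro-Trifluoromethylphenyl Amide

The source may report more compounds than this note shows. Statements on the series, on what has been measured and on what is new or still open speak of the compounds shown alone.

Measured compounds:
compound 1, `Nc1cccc2c(-c3cccc(NC(=O)c4ccc(Cl)c(C(F)(F)F)c4)c3)ccnc12`: 1600 nM
compound 2, `COc1ccc(C(=O)Nc2cccc(-c3ccnc4c(NC(C)=O)cccc34)c2)cc1OC`: 480 nM

Of the compounds shown here, two have been measured in a functional assay on SK-MEL-5 cells (Homo sapiens) for antiproliferative activity, read by sulforhodamine B assay, with a stated time of 48 h; on this read-out lower numbers stand for stronger inhibition and higher numbers for weaker inhibition. Compound 1 gives 1600 nM, and compound 2 gives 480 nM. Compound 2 thus stands at the lower of the two numbers, and its gap to compound 1 lies beyond the usual scatter. The two compounds differ in two places at once, so neither difference can be tied on its own to this gap.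

Compound 3, `CC(=O)Nc1cccc2c(-c3cccc(NC(=O)c4ccc(Cl)c(C(F)(F)F)c4)c3)ccnc12`, has not yet been measured in this assay. It differs from compound 2 in one place: 4-chloro-3-(trifluoromethyl)phenyl in place of 3,4-dimethoxyphenyl on a carbonyl carbon. Going by the values given here, the aryl group that enters is the one carried by compound 1, while the acetamido substituent on the shared core of compound 2 is retained. Among the compounds with values here, no single-change step is available to say which of the two differences between compound 1 and compound 2 matters. In this assay compound 3 is expected to land between the two measured values, with an estimated step of a 1.8-fold higher number from compound 2 to compound 3 (0.25 log units; within the scatter) towards a weaker number. Compound 3 is estimated at 850 nM, with a range from 250 nM to 3000 nM.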

Compound 3, half-maximal inhibitory concentration: 1700 nM
The estimate for compound 3 lay 2.0-fold (0.30 log units) below the measured number, within the range that was stated.
By their numbers in this assay, from the lowest: compound 2; then compounds 1 and 3 (each within the scatter of the next).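

In this assay, the exchange of 3,4-dimethoxyphenyl for 4-chloro-3-(trifluoromethyl)phenyl on a carbonyl carbon, with the acetamido substituent on the shared core retained, gives a 3.5-fold higher number from compound 2 to compound 3 (0.55 log units; beyond the scatter) and so ties a gap beyond the scatter to this aryl group alone, which the first two compounds could not do. The other difference between those two compounds, acetyl in place of hydrogen on a nitrogen on an aromatic ring, gives a 1.1-fold higher number from compound 1 to compound 3 (0.03 log units; within the scatter) and stays within the scatter, so with 4-chloro-3-(trifluoromethyl)phenyl on the carbonyl carbon this change has no effect that can be told apart from repeat measurement. No measurement at hand accounts for the step between the two aryl groups.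

As far as these compounds go, it remains open whether the acetyl change would also stay within the scatter with 3,4-dimethoxyphenyl on the carbonyl carbon, since that comparison rests on a single aryl group. Also open, from the compounds shown here alone, is which part of either aryl group matters, and how a phenyl ring bearing one methoxy group, one chlorine atom or a carboxylic acid would compare at this position.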